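Working notes: swapping the small group on the five-membered ring

The compounds below may be only part of what the source reports. "The series", "measured", "known", "first", "only" and "open" are said of these compounds alone.

compound 1 `COc1ncnc2c1c(-c1cccs1)cn2[C@@H]1O[C@H](CO)[C@@H](O)[C@H]1O`: 6200 nM
compound 2 `COc1ncnc2c1c(-c1ccccc1)cn2[C@@H]1O[C@H](CO)[C@@H](O)[C@H]1O`: > 20000 nM, a limit of the assay, not a number
compound 3 `C#Cc1cn([C@@H]2O[C@H](CO)[C@@H](O)[C@H]2O)c2ncnc(OC)c12`: 380 nM
compound 4 `COc1ncnc2c1c(I)cn2[C@@H]1O[C@H](CO)[C@@H](O)[C@H]1O`: not yet measured

In a functional assay on K562 cells (Homo sapiens), read by MTT assay, with a stated time of 72 h (a lower number here means a stronger inhibitor, a higher number a weaker inhibitor), compound 1 gives 6200 nM. Compound 2 sits at the limit of > 20000 nM in this assay, at which 1 of the 3 values shown sits, so its value is a limit only. Compound 3 gives 380 nM and stands lowest of the two numbers; the step of a 16-fold lower number from compound 1 to compound 3 (1.21 log units; beyond the scatter) separates it from the nearest number, and an at least 52-fold lower number from compound 2 to compound 3 (1.72 log units; beyond the scatter) from the limit. Between the two ring-bearing compounds, an at least 3.2-fold higher number from compound 1 to compound 2 (0.50 log units; beyond the scatter) is the smaller of the three steps.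

Compound 4 differs from compound 3 in one place: iodo in place of ethynyl on an aromatic carbon. For the measured compounds named here, both measured steps that end at compound 3 replace a ring by the ethynyl, so they show only that the small group on this aromatic carbon does well against the rings. Going by the values given here, no measured step involves iodo, and no step exchanges one small group for another, so the direction rests on the size of the group alone. For compound 4 a modest step of a 2.4-fold higher number from compound 3 to compound 4 (0.37 log units; beyond the scatter) is expected, toward a somewhat higher number than the ethynyl gives, with an estimate of 900 nM, between 250 nM and 3500 nM.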

Compound 4, half-maximal inhibitory concentration: 14800 nM
For compound 4 the middle estimate is 16-fold (1.22 log units) below the measured one; the whole stated range lies below it.
By their numbers in this assay, from the lowest: compound 3; then compound 1; then compound 4. At a limit, above all of these: compound 2.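

In this assay, iodo in place of ethynyl gives a 39-fold higher number from compound 3 to compound 4 (1.59 log units; beyond the scatter), so a group without a ring is not enough at this position and the gain seen with ethynyl does not extend to iodo. For the compounds shown here, the ring is not the sole drawback either: a 2.4-fold higher number from compound 1 to compound 4 (0.38 log units; beyond the scatter), which places a ring-bearing compound below the iodo one and leaves ethynyl as the one group here with a clear advantage. Compound 2 is a limit and not a number: the limit of > 20000 nM in this assay, at which 1 of the 4 values shown sits. With iodo in place of phenyl, the step is an at least 1.3-fold lower number from compound 2 to compound 4 (0.13 log units; that floor lies within the scatter), so it sets no order for these two compounds.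

The compounds shown do not separate the triple bond from the rest of the ethynyl group, as vinyl, ethyl and nitrile groups on this aromatic carbon are absent from them. Going by these compounds, whether bromo or chloro would track with iodo also stays open.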